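The source may hold more compounds than are shown below. What is called first, only, known or untested is meant among the compounds shown, and "the series" means these compounds.

Values measured in a functional assay on MDA-MB-436 cells (Homo sapiens) for antiproliferative activity, read by MTT assay, with a stated time of 24 h; on this read-out lower numbers stand for stronger inhibition and higher numbers for weaker inhibition:

- Compound 1 `O=C(O)CC(NC(=O)c1ccc(Cl)cc1Cl)c1ccccc1F`: > 100000 nM
- Compound 2 `O=C(O)CC(NC(=O)c1ccc(F)cc1)c1ccc(Cl)cc1Cl`: 55800 nM
- Compound 3 `O=C(O)CC(NC(=O)c1ccc(C(F)(F)F)cc1)c1ccc(Cl)cc1Cl`: 44100 nM

Only two of these results are actual numbers. Compound 2 gives 55800 nM, and compound 3 lies within the scatter of it, so the two cannot be ranked. Compound 1 sits at the limit of > 100000 nM in this assay, at which 1 of the 3 values shown sits, which is a limit and not a number.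

The next compound to be tested is compound 4 `O=C(O)CC(NC(=O)c1ccc(Cl)cc1Cl)c1ccc(Cl)cc1Cl`. Compared with compound 2, it carries a different group on the carbonyl carbon: 2,4-dichlorophenyl in place of 4-fluorophenyl on a carbonyl carbon.

Among the measured compounds shown here, only one measured step changes the group on this carbonyl carbon: a 1.3-fold lower number from compound 2 to compound 3 (0.10 log units; within the scatter). That exchange left the number inside the usual scatter, even though a fluoro was replaced by a trifluoromethyl. It is a single step, however, and it does not test the 2,4-dichlorophenyl group, so it offers only modest guidance. On that basis, no change beyond the scatter is expected here.

The estimated change is a 1.2-fold lower number from compound 2 to compound 4 (0.09 log units; within the scatter). For compound 4 the expected value is 45000 nM, with an estimated range from 18000 nM to 100000 nM.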

Compound 4, half-maximal inhibitory concentration: 57300 nM
Estimate against measurement, compound 4: 1.3-fold (0.10 log units) below, and the stated range covers the measured number.
By their numbers in this assay, from the lowest: compounds 3, 2 and 4 (each within the scatter of the next). At a limit, above all of these: compound 1.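

At the carbonyl carbon, 2,4-dichlorophenyl in place of 4-fluorophenyl gives a 1.0-fold higher number from compound 2 to compound 4 (0.01 log units; within the scatter) in this assay, and this joins a 1.3-fold lower number from compound 2 to compound 3 (0.10 log units; within the scatter), so all three substituted phenyl groups tried on this carbon leave the number within the scatter, including one that carries two chlorines. Compound 1 gives a limit and not a number: the limit of > 100000 nM in this assay, at which 1 of the 4 values shown sits. On the saturated chain carbon bound to an amide-type nitrogen, 2,4-dichlorophenyl in place of 2-fluorophenyl gives an at least 1.7-fold lower number from compound 1 to compound 4 (0.24 log units; that floor lies within the scatter), and as this step starts from that limit, it gives only a floor, not the true size of the change.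

From the compounds shown here alone, it remains open whether any group on the carbonyl carbon can move the number beyond the scatter, since every group there so far is a substituted phenyl and nothing shows what a pyridine ring, an amine or a longer chain would do at that place. Also open, going by these compounds, is how the number responds on the saturated chain carbon to groups other than 2,4-dichlorophenyl and 2-fluorophenyl, and to an ester in place of the carboxylic acid of the shared core.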